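A few compounds are considered here, and "the series" means these few. Any claim that something is new, unique, unknown or untested is made for them only; others in the source may bear on it.

Measured so far:
compound 1 `Cn1cccc1C(=O)/C=C/c1ccc2c(c1)B(O)OC2` — in a functional assay on MDA-MB-231 cells (Homo sapiens) for cytotoxicity, read by MTT assay, with a stated time of 48 h (a higher number here means a weaker inhibitor, a lower number a stronger inhibitor), compound 1 gives > 100000 nM
compound 2 `CCOC(=O)c1ccc(C(=O)/C=C/c2ccc3c(c2)B(O)OC3)cc1` — in this assay compound 2 gives 13000 nM

The value for compound 1 is a limit of the assay, not a number, and sits at the limit of > 100000 nM in this assay, at which 1 of the 2 values shown sits. Going by the values given here, compound 2, the aryl ketone of the pair, is the only one with a measured number. Compound 3 `O=C(/C=C/c1ccc2c(c1)B(O)OC2)c1ccccc1F` differs from compound 1 by 2-fluorophenyl in place of 1-methyl-1H-pyrrol-2-yl on a carbonyl carbon. Among the compounds with values here, no measured step covers this change, so the size is a guess. For compound 3 the expected step in this assay is an at least 5.0-fold lower number from compound 1 to compound 3 (0.69 log units; beyond the scatter), toward stronger inhibition and beyond the scatter. Compound 3 is thus estimated at 20000 nM, with a range of 6000 nM to 70000 nM.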

Compound 3, half-maximal inhibitory concentration: 2200 nM
Estimate against measurement, compound 3: 9.1-fold (0.96 log units) above; measured number below the stated range.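

Putting 2-fluorophenyl in place of 1-methyl-1H-pyrrol-2-yl on the carbonyl carbon gives an at least 45-fold lower number from compound 1 to compound 3 (1.65 log units; beyond the scatter), so in this assay this position carries a large change in the read-out. The value of compound 1 is a limit of the assay, so the true size of this step stays unknown: the limit of > 100000 nM in this assay, at which 1 of the 3 values shown sits.

The compounds shown leave open whether the fluorine contributes to this step or a plain phenyl on the carbonyl carbon would do the same. On these data alone, whether a pyridine ring or an aminophenyl group is tolerated there also remains open.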